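The source may hold more compounds than are shown below. What is called first, only, known or untested is meant among the compounds shown, and "the series" means these compounds.

Measured compounds:
- compound 1, `COc1cc2c(Oc3ccc(NC(=O)c4nn(-c5ccc(F)cc5)c(=O)c5ccccc45)cc3F)ccnc2cc1OCCCN1CCN(C)CC1`, giving 320 nM in a functional assay on HT-29 cells (Homo sapiens) for cytotoxicity, read by MTT assay, with a stated time of 72 h; a higher number here means a weaker inhibitor, a lower number a stronger inhibitor
- compound 2, `COc1cc2c(Oc3ccc(NC(=O)c4nn(-c5ccccc5F)c(=O)c5ccccc45)cc3F)ccnc2cc1OCCCN1CCN(C)CC1`, giving 480 nM in this assay
- compound 3, `COc1cc2c(Oc3ccc(NC(=O)c4nn(-c5ccc([N+](=O)[O-])cc5)c(=O)c5ccccc45)cc3F)ccnc2cc1OCCCN1CCN(C)CC1`, giving 2560 nM in this assay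

Compound 2 stands second highest of the three numbers in this assay. Its nearest neighbour is compound 1, with a 1.5-fold higher number from compound 1 to compound 2 (0.18 log units; within the scatter); its furthest is compound 3, with a 5.3-fold higher number from compound 2 to compound 3 (0.73 log units; beyond the scatter).

Compound 4, `COc1cc2c(Oc3ccc(NC(=O)c4nn(-c5ccccc5F)c(=O)c5ccccc45)cc3F)ccnc2cc1OCCCN1CCC(C)CC1`, differs from compound 2 in one place: 4-methylpiperidin-1-yl in place of 4-methylpiperazin-1-yl on a saturated chain carbon, three bonds along the chain from an oxygen on an aromatic ring. For the measured compounds named here, none of the measured steps touches this part of the molecule. The steps of a 1.5-fold higher number from compound 1 to compound 2 (0.18 log units; within the scatter) and an 8.0-fold higher number from compound 1 to compound 3 (0.90 log units; beyond the scatter) both alter the aryl group on the aromatic nitrogen and leave the chain amine unchanged, so they give no guide to the size or direction of the change in compound 4. In the absence of a precedent, the expectation for compound 4 in this assay is a number close to that of compound 2, with no step beyond the scatter but a wider range than usual.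

Compound 4 is therefore estimated at 500 nM, within 200 nM to 1500 nM. For compound 4 the expected step is a 1.0-fold higher number from compound 2 to compound 4 (0.02 log units; within the scatter).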

Compound 4, half-maximal inhibitory concentration: 510 nM
For compound 4 the middle estimate is 1.0-fold (0.01 log units) below the measured one, and the stated range covers the measured number.
By their numbers in this assay, from the lowest: compounds 1, 2 and 4 (each within the scatter of the next); then compound 3.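

For the compounds shown here, this is the first change in the set that touches the chain amine rather than the aryl group on the aromatic nitrogen. In this assay the swap of 4-methylpiperazin-1-yl for 4-methylpiperidin-1-yl, with the 2-fluorophenyl group held constant, gives a step that stays within the scatter (a 1.1-fold higher number from compound 2 to compound 4 (0.03 log units; within the scatter)), so at this position one ring nitrogen and one counted hydrogen-bond acceptor can be exchanged without a change that can be told from the scatter. No measurement shown offers an explanation for this result.

The compounds shown leave open whether a morpholin-4-yl ring, a dimethylamino group or a piperidin-1-yl ring without the methyl group would also stay within the scatter here, and how a longer chain would read. They also leave open whether the same swap would read alike with 4-fluorophenyl or 4-nitrophenyl on the aromatic nitrogen.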